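Working notes: chloromethyl in place of (oxiran-2-yl)methoxy

This account rests on a few compounds, and the source may have more. Where it says the series, first, only, none or still open, it means among the compounds named here.

In an ADME assay for pharmacokinetics (a lower number here means that the compound disappears faster, a higher number that the compound lasts longer), compound 2 `CC[C@H](c1ccc(O)cc1)[C@@H](CC)c1ccc(OCC2CO2)cc1` gives 4 h and compound 1 `CC[C@H](c1ccc(O)cc1)[C@@H](CC)c1ccc(CBr)cc1` gives 2.5 h, two numbers within the scatter of each other. Compound 3 `CC[C@H](c1ccc(O)cc1)[C@@H](CC)c1ccc(CCl)cc1` carries the change (chloromethyl in place of (oxiran-2-yl)methoxy on an aromatic carbon), with chloromethyl in place of (oxiran-2-yl)methoxy on an aromatic carbon. For the measured compounds named here, one measured step bears on it: a 1.6-fold higher number from compound 1 to compound 2 (0.20 log units; within the scatter), with bromomethyl as the group replaced by (oxiran-2-yl)methoxy. Going by the values given here, no chloromethyl compound has been measured yet. The expected step of a 1.3-fold lower number from compound 2 to compound 3 (0.12 log units; within the scatter) goes toward a lower number in this assay, but not beyond the scatter. The estimate for compound 3 is 3 h, with an expected range of 1.5 h to 5.5 h.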

Compound 3, half-life: 1.3 h
The estimate for compound 3 lay 2.3-fold (0.36 log units) above the measured number; measured number below the stated range.
By their numbers in this assay, from the lowest: compounds 3, 1 and 2 (each within the scatter of the next, the first and the last beyond it).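

In this assay, this position on the aromatic carbon now shows a step beyond the scatter, though a modest one, with chloromethyl in place of (oxiran-2-yl)methoxy (a 3.1-fold lower number from compound 2 to compound 3 (0.49 log units; beyond the scatter)), which the earlier pair did not show. Chloro in place of bromo on the saturated chain carbon stays within the scatter (a 1.9-fold lower number from compound 1 to compound 3 (0.28 log units; within the scatter)). Nothing available explains either step. Still open, from the compounds shown here alone, is how an amine or a carboxylic acid at this position would compare with chloromethyl and (oxiran-2-yl)methoxy. Going by these compounds, whether a longer chain would behave like either group is also open.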